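The source may hold more compounds than are shown below. What is called first, only, known or untested is meant among the compounds shown, and "the series" means these compounds.

Measured in an assay on Huh-7 cells for agonist activity at Bile acid receptor (Homo sapiens), read by a luciferase reporter; on this read-out higher numbers stand for an effect only at larger amounts of compound and lower numbers for an effect already at smaller amounts:
compound 1 `CCC(CC)n1c(-c2ccc(OCc3c(-c4c(Cl)cccc4Cl)noc3C(C)C)cc2F)nc2ccc(C(=O)O)cc21` — 1.3 nM
compound 2 `CC(C)c1onc(-c2c(Cl)cccc2Cl)c1COc1ccc(-c2nc3ccc(C(=O)O)cc3n2Cc2ccc(F)cc2)cc1` — 3.31 nM
compound 3 `CC(C)c1onc(-c2c(Cl)cccc2Cl)c1COc1ccc(-c2nc3ccc(C(=O)O)cc3n2C2CC2)cc1` — 16.5 nM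

Compound 3 stands highest of the three numbers: compound 2 sits one step below it, a 5.0-fold higher number from compound 2 to compound 3 (0.70 log units; beyond the scatter), and compound 1 sits furthest below. Compound 4 `CC(C)c1onc(-c2c(Cl)cccc2Cl)c1COc1ccc(-c2nc3ccc(C(=O)O)cc3n2CC2CCCCC2)cc1` differs from compound 3 in one place: cyclohexylmethyl in place of cyclopropyl on an aromatic nitrogen. Within the data shown here, only one measured step bears on an exchange at this aromatic nitrogen, a 5.0-fold higher number from compound 2 to compound 3 (0.70 log units; beyond the scatter), in which cyclopropyl took the place of 4-fluorobenzyl and the number rose modestly; compound 1, carrying yet another group on that nitrogen, gives the lowest number of the set. Moving away from cyclopropyl again, compound 4 is therefore expected to give a modestly lower number, a step of about a 4.7-fold lower number from compound 3 to compound 4 (0.67 log units; beyond the scatter). In this assay compound 4 is estimated at 3.5 nM, with a range from 1.2 nM to 10 nM.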

Compound 4, half-maximal effective concentration: 0.52 nM
Beside the measured number, compound 4's estimate is 6.7-fold (0.83 log units) above it, outside the stated range (below it).
By their numbers in this assay, from the lowest: compound 4; then compound 1; then compound 2; then compound 3.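

Cyclohexylmethyl on this aromatic nitrogen brings a 32-fold lower number from compound 3 to compound 4 (1.50 log units; beyond the scatter) as a large step, so the position takes a much bigger saturated group than cyclopropyl and the numbers still fall. With the same one-carbon attachment, cyclohexyl in place of 4-fluorophenyl gives a 6.4-fold lower number from compound 2 to compound 4 (0.80 log units; beyond the scatter) as a modest step, which shows that an aromatic ring on that carbon is not needed for a low number here. Nothing given here accounts for either step. Going by these compounds, whether the ring itself or simply the larger carbon group matters stays open. A straight hexyl chain, a cyclopentylmethyl group or a piperidine ring bearing an amine could help to separate these possibilities.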